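Methoxy in place of trifluoromethyl: notes on the series

The compounds below may be only part of what the source reports. "The series", "measured", "known", "first", "only" and "open" are said of these compounds alone.

In a functional assay on HaCaT cells (Homo sapiens) for inhibition, read by sulforhodamine B assay, with a stated time of 48 h (a higher number here means a weaker inhibitor of growth, a lower number a stronger inhibitor of growth), compound 1 (`CC1(/C=C/c2ccc(C(F)(F)F)cc2)C=CC(=O)O1`) gives 12100 nM, the lower number of the measured pair. Compound 2 (`COc1ccccc1/C=C/C1(C)C=CC(=O)O1`), which carries a methoxy, gives 30800 nM, a gap beyond the usual scatter. Compound 3 (`COc1ccc(/C=C/C2(C)C=CC(=O)O2)cc1`) has methoxy in place of trifluoromethyl on an aromatic carbon. The expected change in this assay is a modest rise toward weaker inhibition of growth, estimated as a 2.1-fold higher number from compound 1 to compound 3 (0.33 log units; beyond the scatter). For the measured compounds named here, the only guide is compound 2 at 30800 nM. The estimate for compound 3 is 26000 nM, with an expected range of 11000 nM to 60000 nM.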

Compound 3, concentration for total growth inhibition: 316000 nM
Compound 3: the middle estimate sits 12-fold (1.08 log units) below what was measured; the measured number lies above the stated range.
By their numbers in this assay, from the lowest: compound 1; then compound 2; then compound 3.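

In this assay, methoxy in place of trifluoromethyl on an aromatic carbon, para to a group of 9 heavy atoms, gives a large step, a 26-fold higher number from compound 1 to compound 3 (1.42 log units; beyond the scatter), the first single-place change readable in the series. Growth inhibition is therefore highly sensitive to the group at this position. No measurement here accounts for the size of the step.

Going by these compounds, whether a chlorine or an amine at this position would read closer to compound 1 or to compound 3 remains open. Also open, on these data alone, is whether the same exchange would have a similar effect on other cores.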